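A Longer Cyclopentyl Chain on the Shared Core

The source may report more compounds than this note shows. Statements on the series, on what has been measured and on what is new or still open speak of the compounds shown alone.

In a functional assay on PC-3 cells (Homo sapiens) for antiproliferative activity, read by sulforhodamine B assay (on this read-out lower numbers stand for stronger inhibition of growth and higher numbers for weaker inhibition of growth), compound 1 (`CC(C)(C)CCOc1cccc(O)c1C(=O)/C=C/c1ccc(C(=O)O)cc1`) gives 6500 nM. Compound 2 (`O=C(/C=C/c1ccc(O)cc1)c1c(O)cccc1OCC1CCCC1`) gives 3040 nM, the lower of the two numbers, and the gap between them lies beyond the scatter. Compound 3 (`O=C(/C=C/c1ccc(O)cc1)c1c(O)cccc1OCCC1CCCC1`) has not yet been measured. It has cyclopentylmethyl in place of cyclopentyl on a saturated chain carbon bound to an oxygen on an aromatic ring, so that cyclopentylmethoxy becomes 2-cyclopentylethoxy. For the measured compounds named here, no measured pair shows a single change of this kind, so the data offer no direct guide to its effect. No change beyond the scatter is therefore expected in this assay, and no direction is favoured. The estimated step of a 1.1-fold lower number from compound 2 to compound 3 (0.04 log units; within the scatter) is expected to remain small. For compound 3, the estimate is 2800 nM, with an expected range of 1200 nM to 6500 nM.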

Compound 3, concentration for 50% growth inhibition: 3480 nM
Compound 3: the middle estimate sits 1.2-fold (0.09 log units) below what was measured, within the range that was stated.
By their numbers in this assay, from the lowest: compounds 2, 3 and 1 (each within the scatter of the next, the first and the last beyond it).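

For the compounds shown here, the step from cyclopentylmethoxy to 2-cyclopentylethoxy is the first single change that can be read at this position, on a saturated chain carbon bound to an oxygen on an aromatic ring. In this assay it amounts to a 1.1-fold higher number from compound 2 to compound 3 (0.06 log units; within the scatter), so on this core the longer cyclopentyl chain leaves growth inhibition within the scatter of the shorter one. No measurement at hand bears on why the two compounds stand so close.

The compounds shown leave open whether a still longer chain, a cyclohexyl ring in place of cyclopentyl, or an amine at the end of the chain would hold this level. They also leave open whether the same chain change would behave alike on the core of compound 1.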